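Aryl exchange on the aromatic nitrogen: compound 2 to compound 3

This account rests on a few compounds, and the source may have more. Where it says the series, first, only, none or still open, it means among the compounds named here.

Compound 1 (`COc1ccccc1-n1c(-c2coc3cc(C)c(Cl)cc3c2=O)nc(-c2ccccc2)c1-c1ccccc1`) gives 25000 nM in a functional assay on MCF7 cells (Homo sapiens) for inhibition, read by MTT assay, with a stated time of 72 h (on this read-out lower numbers stand for stronger inhibition and higher numbers for weaker inhibition), and compound 2 (`Cc1cc2occ(-c3nc(-c4ccccc4)c(-c4ccccc4)n3-c3ccc(Cl)c(Cl)c3)c(=O)c2cc1Cl`) stands lowest of the measured pair at 1560 nM. Compound 3 (`Cc1cccc(-n2c(-c3coc4cc(C)c(Cl)cc4c3=O)nc(-c3ccccc3)c2-c2ccccc2)c1`) has 3-methylphenyl in place of 3,4-dichlorophenyl on an aromatic nitrogen. Going by the values given here, the only measured step at this place is a 16-fold lower number from compound 1 to compound 2 (1.20 log units; beyond the scatter), a large one. Among the compounds with values here, no measured compound carries 3-methylphenyl, so this step gives only a loose guide. A moderate move to a higher number, smaller than that step, is expected in this assay: an estimated 3.8-fold higher number from compound 2 to compound 3 (0.59 log units; beyond the scatter). For compound 3 the estimate is 6000 nM, with an expected range of 1800 nM to 20000 nM.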

Compound 3, half-maximal inhibitory concentration: 12500 nM
Compound 3: the middle estimate sits 2.1-fold (0.32 log units) below what was measured; measured number inside the range.
By their numbers in this assay, from the lowest: compound 2; then compounds 3 and 1 (each within the scatter of the next).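

In this assay, the low number of compound 2 does not carry over to 3-methylphenyl on the aromatic nitrogen (an 8.0-fold higher number from compound 2 to compound 3 (0.90 log units; beyond the scatter)). Set against 2-methoxyphenyl, 3-methylphenyl gives no separable result (a 2.0-fold lower number from compound 1 to compound 3 (0.30 log units; within the scatter)), so among these three aryl groups only 3,4-dichlorophenyl stands apart. Nothing at hand accounts for this difference.

As far as these compounds go, whether both chlorines are needed remains open, and a 3-chlorophenyl or 4-chlorophenyl group would test this. From the compounds shown here alone, how an aminophenyl or carboxyphenyl group would read at this place is also open.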